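The source may report more compounds than this note shows. Statements on the series, on what has been measured and on what is new or still open speak of the compounds shown alone.

Measured compounds: compound 1 `CCOC(=O)C1=C(C)NC(C)=C(C(=O)OC)C1c1csc(-c2ccc(Cl)cc2)n1` gives 22000 nM in an assay on isolated protein for antagonist activity at Voltage-dependent L-type calcium channel subunit alpha-1C (Cavia porcellus), with a stated time of 15 min; on this read-out higher numbers stand for weaker inhibition and lower numbers for stronger inhibition; compound 2 `CCOC(=O)C1=C(C)NC(C)=C(C(=O)OCC(C)C)C1c1csc(-c2ccc(Cl)cc2)n1` gives 15400 nM; compound 3 `COC(=O)C1=C(C)NC(C)=C(C(=O)OCc2ccccc2)C1c1csc(-c2ccc(Cl)cc2)n1` gives 64900 nM.

Compound 3 stands highest of the three, that is, weakest in this assay; its nearest neighbour is compound 1, a step of a 3.0-fold higher number from compound 1 to compound 3 (0.47 log units; beyond the scatter) away. Compound 4 `CCOC(=O)C1=C(C)NC(C)=C(C(=O)OCc2ccccc2)C1c1csc(-c2ccc(Cl)cc2)n1` differs from compound 3 by methyl in place of hydrogen on a saturated chain carbon bound to an oxygen next to a carbonyl group. Going by the values given here, the closest precedent is the lengthening of an ester chain on the shared core from compound 1 to compound 2, which gave a 1.4-fold lower number from compound 1 to compound 2 (0.15 log units; within the scatter), while the larger swap from compound 1 to compound 3 gave a 3.0-fold higher number from compound 1 to compound 3 (0.47 log units; beyond the scatter). A one-carbon extension is therefore expected to move the number little, if at all, giving an estimated step of a 1.3-fold lower number from compound 3 to compound 4 (0.11 log units; within the scatter). Compound 4 is estimated at 50000 nM, with a range from 22000 nM to 115000 nM.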

Compound 4, half-maximal inhibitory concentration: 3290 nM
Compound 4: the middle estimate sits 15-fold (1.18 log units) above what was measured; the whole stated range lies above it.
By their numbers in this assay, from the lowest: compound 4; then compounds 2 and 1 (each within the scatter of the next); then compound 3.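

Changing methoxy to ethoxy adds only one methyl, yet it gives a 20-fold lower number from compound 3 to compound 4 (1.30 log units; beyond the scatter) in this assay, so a single carbon at this ester can matter greatly when the other ester chain carries phenyl. With ethoxy in place, phenyl in place of hydrogen gives a 6.7-fold lower number from compound 1 to compound 4 (0.83 log units; beyond the scatter), and phenyl in place of isopropyl gives a 4.7-fold lower number from compound 2 to compound 4 (0.67 log units; beyond the scatter), which makes compound 4 the strongest of the four. Nothing measured here explains these steps.

The compounds shown leave open whether a longer chain, such as propoxy in place of ethoxy, would lower the number further. They also leave open whether an amine on the phenyl-bearing ester chain would keep this inhibition.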